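A few compounds are considered here, and "the series" means these few. Any claim that something is new, unique, unknown or untested is made for them only; others in the source may bear on it.

In a functional assay on A549 cells (Homo sapiens) for antiproliferative activity, read by MTT assay, with a stated time of 72 h (a lower number here means a stronger inhibitor, a higher number a weaker inhibitor), compound 1 (`O=C1COc2ccc(-c3cccc(NS(=O)(=O)c4ccc(F)cc4)c3)cc2N1`) gives 32100 nM. In the same test, compound 3 (`COc1ncc(-c2ccc3c(c2)N(C2CC2)C(=O)CO3)cc1NS(=O)(=O)c1ccc(F)cc1`) gives 3320 nM, a lower number than that of compound 1 and thus the stronger reading of the two. Compound 2 (`O=C1COc2ccc(-c3cnc4ccccc4c3)cc2N1C1CCCCC1`) gives no number, only a limit of the assay, > 40000 nM. As far as these compounds go, its true position on the scale therefore remains open.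

Compound 4 (`COc1ccc(N2C(=O)COc3ccc(-c4cnc5ccccc5c4)cc32)cc1`) keeps the rest of compound 2 but carries 4-methoxyphenyl in place of cyclohexyl on an amide-type nitrogen in a ring. For the measured compounds named here, no two measured compounds differ in one place only, so the set offers no direct measure of what a change at this nitrogen does in this assay. The expectation must start from compound 2 and its limit of > 40000 nM. With so little to go on, the expected change, an at least 1.1-fold lower number from compound 2 to compound 4 (0.05 log units; that floor lies within the scatter), is none beyond the scatter, and compound 4 may well return only a limit too. A number somewhat lower remains possible, and compound 3, at 3320 nM, shows that much lower numbers do occur in this set. For compound 4 the estimated value is 35000 nM, with an expected range of 12000 nM to 60000 nM.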

Compound 4, half-maximal inhibitory concentration: > 40000 nM
Compound 4: no number, only a limit (the forecaster's own chance of this, stated with the estimate: 55%); middle value at least 1.1-fold (0.05 log units) away from the limit.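

In this assay, for the compounds shown here, compound 4 returns only a limit, as compound 2 does, so no step between compound 2 and compound 4 can be read: the limit of > 40000 nM in this assay, at which 2 of the 4 values shown sit. The compounds shown leave open whether 4-methoxyphenyl in place of cyclohexyl on the amide-type nitrogen changes the antiproliferative reading at all, and how far either compound lies beyond that limit.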